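The compounds below may be only part of what the source reports. "The series", "measured", "known", "first", "only" and "open" are said of these compounds alone.

Compound 1 `COC(=O)[C@@H](NC(=O)CSC1=C(C)C(=O)c2ccccc2C1=O)C(C)C`: 20000 nM
Compound 2 `COC(=O)CNC(=O)CSC1=CC(=O)c2cccc(OC)c2C1=O`: > 100000 nM
Compound 3 `COC(=O)[C@H](CC(C)C)NC(=O)CSC1=C(OC)C(=O)c2ccccc2C1=O`: 63000 nM

All three were tested in a functional assay on HeLa cells (Homo sapiens) for cytotoxicity, read by MTT assay, with a stated time of 48 h; a lower number here means a stronger inhibitor, a higher number a weaker inhibitor. The entry for compound 2 is a limit of the assay, not a number. Of the two true numbers, compound 3 holds the higher, so it is the weaker inhibitor, and the gap to compound 1 lies beyond the scatter.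

Compound 4 `COC(=O)CCCNC(=O)CSC1=C(OC)C(=O)c2ccccc2C1=O` has 3-(methoxycarbonyl)propyl in place of 1-(methoxycarbonyl)-3-methylbutyl on an amide-type nitrogen. Within the data shown here, no measured pair isolates this change, so no shift beyond the scatter is expected in this assay. The expected step is small, a 1.1-fold higher number from compound 3 to compound 4 (0.05 log units; within the scatter). Compound 4 is expected at 70000 nM, with an estimated range of 25000 nM to 150000 nM.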

Compound 4, half-maximal inhibitory concentration: 24000 nM
Compound 4: middle estimate off by 2.9-fold (0.46 log units), on the high side; the whole stated range lies above it.
By their numbers in this assay, from the lowest: compounds 1 and 4 (each within the scatter of the next); then compound 3. At a limit, above all of these: compound 2.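

Among these compounds, compound 3 and compound 4 differ in one place only, the chain on the amide-type nitrogen, so this is the first pair to isolate a change there. In this assay, 3-(methoxycarbonyl)propyl in place of 1-(methoxycarbonyl)-3-methylbutyl gives a 2.6-fold lower number from compound 3 to compound 4 (0.42 log units; beyond the scatter), which shows that this position can move the result, even though the change also removes the defined stereocentre. Nothing shown gives a cause for this step.

Going by these compounds, whether chain length, branching or the stereocentre carries the step remains open. So does how a longer chain, or a carboxylic acid in place of the methoxycarbonyl end, would behave at this nitrogen.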